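Pentyl for Phenyl on the Carbamate of a Selenocyanate

This account rests on a few compounds, and the source may have more. Where it says the series, first, only, none or still open, it means among the compounds named here.

Values in a functional assay on MCF7 cells (Homo sapiens) for cytotoxicity, read by MTT assay, with a stated time of 72 h; on this read-out lower numbers stand for stronger inhibition of growth and higher numbers for weaker inhibition of growth:
Compound 1, `N#C[Se]c1ccc(NC(=O)OCc2ccc([N+](=O)[O-])cc2)cc1`: 11800 nM
Compound 2, `N#C[Se]c1ccc(NC(=O)OCc2ccccc2)cc1`: 8700 nM
Compound 3, `C=CCOC(=O)Nc1ccc([Se][Se]c2ccc(NC(=O)OCC=C)cc2)cc1`: 20800 nM

Compound 2 gives the lowest of the three numbers in this assay. Its nearest neighbour is compound 1, and the step of a 1.4-fold lower number from compound 1 to compound 2 (0.13 log units; within the scatter) is within the scatter. Compound 3 stands furthest, its value lying beyond the scatter from that of compound 2.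

Compound 4, `CCCCCCOC(=O)Nc1ccc([Se]C#N)cc1`, differs from compound 2 in one place: pentyl in place of phenyl on a saturated chain carbon bound to an oxygen next to a carbonyl group. Within the data shown here, the only measured step, a 1.4-fold lower number from compound 1 to compound 2 (0.13 log units; within the scatter), concerns a nitro on the aromatic ring and says nothing about the carbamate chain, so no measured step bears on this change. The writer therefore expects no step beyond the scatter, a 1.0-fold higher number from compound 2 to compound 4 (0.01 log units; within the scatter). For compound 4 the estimate in this assay is 9000 nM, within 4000 nM to 20000 nM.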

Compound 4, concentration for 50% growth inhibition in the MCF7 assay: 6600 nM
Estimate against measurement, compound 4: 1.4-fold (0.13 log units) above; the range from low to high includes it.
By their numbers in the MCF7 assay, from the lowest: compounds 4, 2, 1 and 3 (each within the scatter of the next, the first and the last beyond it).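

In the MCF7 assay, the step from phenyl to pentyl is a 1.3-fold lower number from compound 2 to compound 4 (0.12 log units; within the scatter), which shows that this position, on a saturated chain carbon bound to an oxygen next to a carbonyl group, can carry a group with no ring without a step beyond the scatter. The same change does register in a physicochemical assay, with a stated time of 180 min, tested at 0.5 mg/mL; a lower number here means less inhibition, a higher number more inhibition at the concentration tested (going by the name of the read-out): compound 2 gives 3.7%, and the step is a number at least 21.3 percentage points higher from compound 2 to compound 4 (beyond the scatter). In the physicochemical assay compound 4 gives > 25%, which is a limit of the assay and not a number: the limit of > 25% in the physicochemical assay, at which 1 of the 2 values shown sits.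

The compounds shown leave open how a longer chain, an amine or a carboxylic acid in place of pentyl would read in the MCF7 assay.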